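Bromo to Methyl on the Benzyl Ether of a Chromone

A few compounds are considered here, and "the series" means these few. Any claim that something is new, unique, unknown or untested is made for them only; others in the source may bear on it.

Measured compounds:
compound 1, `O=c1ccoc2ccc(OCCc3ccccc3)cc12`: 3120 nM
compound 2, `O=c1ccoc2ccc(OCc3cccc(Br)c3)cc12`: 386 nM

Of the compounds shown here, two of this set have been tested in an assay on microsomes for inhibition of Amine oxidase [flavin-containing] A (Homo sapiens), read by fluorescence and spectrophotometry, with a stated time of 20 min; on this read-out higher numbers stand for weaker inhibition and lower numbers for stronger inhibition. Compound 1, `O=c1ccoc2ccc(OCCc3ccccc3)cc12`, gives 3120 nM. Compound 2, `O=c1ccoc2ccc(OCc3cccc(Br)c3)cc12`, gives 386 nM, the lower of the two numbers and therefore the stronger inhibition; the gap between the two values is beyond the usual scatter. These two compounds differ at more than one place, so no single change accounts for the gap.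

Compound 3, `Cc1cccc(COc2ccc3occc(=O)c3c2)c1`, has not been measured. It differs from compound 2 in one place: methyl in place of bromo on an aromatic carbon. Among the compounds with values here, no measured pair shows what this particular exchange does to inhibition of this enzyme, so the expectation rests on compound 2 alone, 386 nM, and on the observation that the bromo-substituted benzyl ether of compound 2 gives the stronger inhibition of the two compounds measured. For this change a modest step toward weaker inhibition of about a 2.1-fold higher number from compound 2 to compound 3 (0.32 log units; beyond the scatter) is expected, within a range that also admits no change beyond the scatter. Compound 3 is therefore estimated at 800 nM, with a range from 250 nM to 2500 nM.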

Compound 3, half-maximal inhibitory concentration: 1130 nM
Compound 3: middle estimate off by 1.4-fold (0.15 log units), on the low side; the measured number falls inside the stated range.
By their numbers in this assay, from the lowest: compound 2; then compound 3; then compound 1.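

In this assay, the exchange of bromo for methyl on an aromatic carbon, meta to a large group, gives a 2.9-fold higher number from compound 2 to compound 3 (0.47 log units; beyond the scatter), a modest loss of inhibition that lies beyond the scatter. Within the data shown here, this is the first comparison in the set in which only one place changes, and it shows that inhibition depends on what this carbon of the benzyl ether carries: two groups of one heavy atom each, neither with a hydrogen-bond donor or acceptor and neither charged, do not give the same number, and bromo gives the stronger inhibition. Nothing at hand gives a reason for the difference between bromo and methyl.

The compounds shown leave open what a chloro, a methoxy or an amine would give at this carbon, and whether any of them would match or pass bromo. They also leave open whether the exchange of bromo for methyl would give a step of similar size elsewhere on that ring, or on the longer chain that compound 1 carries.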